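The source may hold more compounds than are shown below. What is called first, only, known or untested is meant among the compounds shown, and "the series" means these compounds.

Measured so far in a functional assay on HCT-116 cells (Homo sapiens), read by MTT assay, with a stated time of 72 h (on this read-out higher numbers stand for weaker inhibition and lower numbers for stronger inhibition), each value being a limit of the assay and not a number:

- compound 1 `CNc1ncnc2c1c(-c1cccs1)cn2[C@@H]1O[C@H](CO)[C@@H](O)[C@H]1O`: > 20000 nM
- compound 2 `CNc1ncnc2c1c(-c1ccsc1)cn2[C@@H]1O[C@H](CO)[C@@H](O)[C@H]1O`: > 20000 nM
- compound 3 `C#Cc1cn([C@@H]2O[C@H](CO)[C@@H](O)[C@H]2O)c2ncnc(NC)c12`: > 20000 nM

Compound 2 stands at > 20000 nM, which is a limit. It has no number to rank it against the other two compounds, and the whole set looks the same: the limit of > 20000 nM in this assay, at which 3 of the 3 values shown sit.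

Compound 4 `CN(C)c1ncnc2c1c(-c1ccsc1)cn2[C@@H]1O[C@H](CO)[C@@H](O)[C@H]1O` differs from compound 2 in one place: methyl in place of hydrogen on a nitrogen on an aromatic ring. This puts methyl in place of hydrogen on a nitrogen on an aromatic ring, turning methylamino into dimethylamino.

The measured steps offer little guidance. All three change a group on an aromatic carbon, not this nitrogen, and none has a readable size: a step that the two limits leave unreadable from compound 1 to compound 2, a step that the two limits leave unreadable from compound 1 to compound 3 and a step that the two limits leave unreadable from compound 2 to compound 3. No step beyond the usual scatter can therefore be forecast in either direction, and the expected change is a step that the limit leaves unreadable from compound 2 to compound 4. Another limit is the most likely report in this assay. For compound 4 the estimate is 25000 nM, with an expected range from 10000 nM to 60000 nM.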

Compound 4, half-maximal inhibitory concentration: > 20000 nM
Compound 4 gave a limit, no number; the forecaster's own chance of this, stated with the estimate: 90%; the middle value lies beyond the limit too.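

Compound 4 gives a limit, not a number, as compound 2 does, so the step between compound 2 and compound 4 cannot be read, and neither can any other step here: the limit of > 20000 nM in this assay, at which 4 of the 4 values shown sit.

Left open is how strongly any of these compounds acts in this assay and whether dimethylamino differs from methylamino at all.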